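This account rests on a few compounds, and the source may have more. Where it says the series, first, only, none or still open, it means among the compounds named here.

Measured in an assay on isolated protein for inhibition of protein kinase C zeta type (Homo sapiens), read by 33P incorporation, tested at 50 uM; on this read-out lower numbers stand for a weaker effect and higher numbers for a stronger effect at the one concentration tested:
compound 1 `O=C(O)CC(Cc1nc2cc(Br)ccc2[nH]1)c1ccc(Cl)cc1` gives 25%
compound 2 `CCc1ccc2[nH]c(CC(CC(=O)O)c3ccc(Cl)cc3)nc2c1` gives 0%

Going by the values given here, compound 2 stands lowest of the two numbers in this assay; its only neighbour is compound 1, which sits higher. Among the compounds with values here, the single measured step, a number 25 percentage points lower from compound 1 to compound 2 (beyond the scatter), came with ethyl in place of bromo on an aromatic carbon and lies beyond the scatter.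

Compound 3 `COc1ccc2[nH]c(CC(CC(=O)O)c3ccc(Cl)cc3)nc2c1` has not yet been measured. It differs from compound 2 in one place: methoxy in place of ethyl on an aromatic carbon. Within the data shown here, no measured step swaps ethyl for methoxy, so a number 25 percentage points lower from compound 1 to compound 2 (beyond the scatter) bears on it only loosely: it shows that a change at this aromatic carbon went with a modest drop, and that compound 2, carrying ethyl, sits at the bottom of the two. With no direct guide, compound 3 is expected to remain close to where it starts, a step of a number 5 percentage points higher from compound 2 to compound 3 (within the scatter), with no change beyond the scatter as the most likely outcome. Compound 3 is therefore estimated at 5%, within a range from -5% to 25%.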

Compound 3, a percentage reported as inhibition, at one concentration (the size of the read-out at that concentration, not a potency): 0%
Estimate against measurement, compound 3: 5 percentage points above, and the stated range covers the measured number.
By their numbers in this assay, from the lowest: compounds 2 and 3 (each within the scatter of the next); then compound 1.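

In this assay, methoxy in place of ethyl on this aromatic carbon gives no change at the digits printed from compound 2 to compound 3 (within the scatter), so exchanging one two-heavy-atom group for another, this time with a hydrogen-bond acceptor, leaves the reading where it was. Methoxy in place of bromo gives a number 25 percentage points lower from compound 1 to compound 3 (beyond the scatter), the same size of step that ethyl gave, which means the earlier drop was not particular to ethyl: among the three groups seen at this position, only bromo goes with a reading above the others. No measurement here explains why bromo stands apart from ethyl and methoxy.

Compound 2 and compound 3 give the same reading at the single concentration tested, so any smaller difference between ethyl and methoxy cannot be seen in this read-out. On these data alone, it remains open whether the higher reading belongs to bromo alone or extends to other halogens such as chloro or fluoro, and how plain hydrogen, an amine or a nitrile on this same carbon would compare.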